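Succinimide series: N-substituent change with 2-oxocyclohexyl kept

The source may report more compounds than this note shows. Statements on the series, on what has been measured and on what is new or still open speak of the compounds shown alone.

Measured so far:
compound 1 `CC(=O)CC1CC(=O)N(c2ccccc2)C1=O`, 63900 nM
compound 2 `O=C1CCCCC1C1CC(=O)N(Cc2ccccc2)C1=O`, 20000 nM

Going by the values given here, in an assay on Sf21 cells for inhibition of cytochrome c oxidase subunit 2 (Homo sapiens), read by spectrophotometry, with a stated time of 5 min (a lower number here means a stronger inhibitor, a higher number a weaker inhibitor), compound 2 gives the lowest of the two numbers so far, and compound 1 gives 63900 nM, a higher number beyond the scatter. Among the compounds with values here, compound 1 and compound 2 differ in two places at once, so the two values give no clean single step; they show only that compound 2 is the stronger inhibitor of the pair.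

Compound 3 `O=C1CCCCC1C1CC(=O)N(c2ccc(Br)cc2)C1=O` keeps the 2-oxocyclohexyl group of compound 2 and changes the ring nitrogen substituent:
4-bromophenyl in place of benzyl on an amide-type nitrogen in a ring

Within the data shown here, no one-place step between measured compounds is known. In this assay a step from compound 2 to compound 3 that is small and toward a higher number is expected, likely not beyond the scatter, as the higher number of the pair belongs to the aryl-on-nitrogen compound 1 with 63900 nM, though compound 1 carries a second change too. Compound 3 is estimated at 30000 nM, range 8000 nM to 100000 nM, meaning an expected step of a 1.5-fold higher number from compound 2 to compound 3 (0.18 log units; within the scatter).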

Compound 3, half-maximal inhibitory concentration: 113000 nM
For compound 3 the middle estimate is 3.8-fold (0.58 log units) below the measured one; the whole stated range lies below it.
By their numbers in this assay, from the lowest: compound 2; then compounds 1 and 3 (each within the scatter of the next).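

In this assay, going by these compounds alone, the ring nitrogen with the 2-oxocyclohexyl group kept gives the first readable one-place step: 4-bromophenyl in place of benzyl brings a 5.7-fold higher number from compound 2 to compound 3 (0.75 log units; beyond the scatter), a modest loss of inhibition. The position therefore responds to this change even though the entering and leaving groups match in heavy-atom count, each carrying one six-membered aromatic ring of carbon only, no hydrogen-bond donors or acceptors and no net charge. No measurement at hand explains the loss.

The step swaps benzyl as a whole, leaving the effect of the bromine apart from that of the benzyl carbon unresolved. A 4-bromobenzyl or plain phenyl group on this nitrogen, with the 2-oxocyclohexyl group kept, would separate the two, and a longer chain such as 2-phenylethyl would test the reach of the position.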